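The source may hold more compounds than are shown below. What is called first, only, known or untested is meant among the compounds shown, and "the series" means these compounds.

Measured so far in a functional assay on SW-620 cells (Homo sapiens) for cytotoxicity, read by MTT assay, with a stated time of 48 h; a lower number here means a stronger inhibitor, a higher number a weaker inhibitor:
compound 1 `CCCCCCCCCCCCCCNC(=O)[C@@H](N)[C@@H](C)O` gives 18700 nM
compound 2 `CCCCCCCCNC(=O)[C@@H](NC(=O)c1cccs1)[C@@H](C)O` gives 136000 nM
compound 3 `CCCCCCCCCCCCCCNC(=O)[C@@H](NC(=O)c1ccco1)[C@@H](C)O` gives 200000 nM

Compound 3 has the highest number of the three in this assay. Within the data shown here, compound 2 is nearest, its number lying within the scatter of that of compound 3; compound 1 is furthest, and that pair is the one measured step: an 11-fold higher number from compound 1 to compound 3 (1.03 log units; beyond the scatter). Compound 4 `CCCCCCCCCCCCCCNC(=O)[C@@H](NC(=O)c1cccs1)[C@@H](C)O` has not been measured. It differs from compound 3 by thiophen-2-yl in place of furan-2-yl on a carbonyl carbon. Among the measured compounds shown here, no measured step covers this exchange: the step from compound 1 to compound 3 concerns the carbonyl-bearing group as a whole, not the ring within it, and compound 2, which carries the thiophen-2-yl, also carries a shorter chain, so its value and that of compound 3 show only that the two numbers lie within the scatter of each other. With nothing in the measured data pointing either way, the expected step is a 1.3-fold lower number from compound 3 to compound 4 (0.10 log units; within the scatter), none beyond the scatter. Compound 4 is therefore estimated at 160000 nM in this assay, between 60000 nM and 400000 nM.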

Compound 4, half-maximal inhibitory concentration: 78400 nM
For compound 4 the middle estimate is 2.0-fold (0.31 log units) above the measured one; the range from low to high includes it.
By their numbers in this assay, from the lowest: compound 1; then compounds 4, 2 and 3 (each within the scatter of the next, the first and the last beyond it).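

In this assay the ring on the carbonyl carbon matters in its own right: with the chain held constant, thiophen-2-yl in place of furan-2-yl gives a step beyond the scatter (a 2.6-fold lower number from compound 3 to compound 4 (0.41 log units; beyond the scatter)), which the earlier step, covering the whole carbonyl-bearing group, could not separate. Among the thiophen-2-yl amides, the added hexyl gives a step within the scatter (a 1.7-fold lower number from compound 2 to compound 4 (0.24 log units; within the scatter)), so this pair shows no readable effect of chain length. Adding (thiophen-2-yl)carbonyl to the free amine still gives a higher number (a 4.2-fold higher number from compound 1 to compound 4 (0.62 log units; beyond the scatter)), so both acylated compounds with the longer chain lie beyond the scatter of compound 1.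

From the compounds shown here alone, whether a phenyl ring on the carbonyl carbon, or a chain longer than that of compound 4, would extend this trend remains open. The data offer no explanation for the difference between the two rings.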